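Replacing the nitro-bearing aryl group in compound 2

The source may hold more compounds than are shown below. What is called first, only, known or untested is meant among the compounds shown, and "the series" means these compounds.

The measured compounds are:
compound 1, `O=C(/C=C/c1ccc(Oc2ncnc3ccc(Cl)cc23)cc1)/C=C/c1cc([N+](=O)[O-])ccc1Cl`, giving 3150 nM in a functional assay on PC-3 cells (Homo sapiens) for inhibition, read by MTT assay, with a stated time of 72 h; a lower number here means a stronger inhibitor, a higher number a weaker inhibitor;
compound 2, `O=C(/C=C/c1ccc(Oc2ncnc3ccc(Cl)cc23)cc1)/C=C/c1ccc(Cl)c([N+](=O)[O-])c1`, giving 11800 nM in this assay.

Among the measured compounds shown here, compound 2 stands at the higher of the two numbers, with compound 1 as its only neighbour; the single measured step, a 3.7-fold higher number from compound 1 to compound 2 (0.57 log units; beyond the scatter), lies beyond the scatter and is modest in size. Compound 3, `O=C(/C=C/c1ccc(Oc2ncnc3ccc(Cl)cc23)cc1)/C=C/c1cccc(Cl)c1Cl`, is not yet measured. Its change from compound 2 is 2,3-dichlorophenyl in place of 4-chloro-3-nitrophenyl on a double-bonded chain carbon bound to a double-bonded chain carbon. For the measured compounds named here, only the step from compound 1 to compound 2 bears on this, and only loosely: that step rearranged the nitro and chloro groups on the same ring, whereas here the nitro group leaves and a second chlorine enters. Since both measured values sit within a modest span, and compound 2 holds the weaker end, the expected result for compound 3 is a small lowering of the number, a 2.0-fold lower number from compound 2 to compound 3 (0.29 log units; within the scatter), though with low confidence in the direction. Compound 3 is therefore estimated at 6000 nM in this assay, with a range of 1800 nM to 20000 nM.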

Compound 3, half-maximal inhibitory concentration: 10200 nM
The estimate for compound 3 lay 1.7-fold (0.23 log units) below the measured number, and the stated range covers the measured number.
By their numbers in this assay, from the lowest: compound 1; then compounds 3 and 2 (each within the scatter of the next).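

In this assay, putting 2,3-dichlorophenyl in place of 4-chloro-3-nitrophenyl on a double-bonded chain carbon bound to a double-bonded chain carbon gives a 1.2-fold lower number from compound 2 to compound 3 (0.06 log units; within the scatter) and so does not separate the two compounds, even though the nitro group has left and a second chlorine has entered. The same 2,3-dichlorophenyl group in place of 2-chloro-5-nitrophenyl gives a 3.2-fold higher number from compound 1 to compound 3 (0.51 log units; beyond the scatter), so among these three compounds the presence of a nitro group does not by itself set the number: compound 1 and compound 2 both carry one, yet only compound 1 stands apart, while compound 2 and compound 3 stay together. Nothing available here accounts for the distinct standing of 2-chloro-5-nitrophenyl at this position.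

The compounds shown leave open whether that standing depends on the nitro group of compound 1 or on the particular arrangement of its two groups on the ring. They also do not show how an amine or a carboxylic acid in place of that nitro group would read in this assay.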